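Thiomorpholine to piperidine on the thiocarbonyl carbon

This account rests on a few compounds, and the source may have more. Where it says the series, first, only, none or still open, it means among the compounds named here.

Compound 2 `Cc1ccnc(/C(N)=N/NC(=S)N2CCSCC2)c1` gives 39.2% in a functional assay on HeLa cells (Homo sapiens) for cytotoxicity, read by MTT assay, with a stated time of 72 h, tested at 10 uM (on this read-out higher numbers stand for more inhibition of growth at the one concentration tested and lower numbers for less inhibition of growth), and stands lowest of the three measured numbers, with compound 3 `N/C(=N\NC(=S)N1CCSCC1)c1ccccn1` nearest at 54.5% and compound 1 `Cc1cccc(/C(N)=N/NC(=S)N2CCSCC2)n1` furthest at 67.6%. Compound 4 `Cc1ccnc(/C(N)=N/NC(=S)N2CCCCC2)c1` differs from compound 2 by piperidin-1-yl in place of thiomorpholin-4-yl on a thiocarbonyl carbon. Neither measured step touches this part of the molecule: a number 13.1 percentage points lower from compound 1 to compound 3 (beyond the scatter) and a number 15.3 percentage points higher from compound 2 to compound 3 (beyond the scatter) both concern hydrogen in place of methyl on an aromatic carbon and are of modest size. For the measured compounds named here, no step replaces the thiomorpholin-4-yl group, so the data give no direction for this change; the expectation in this assay is a step no larger than those seen, most likely none beyond the scatter. Compound 4 is therefore expected near compound 2, at 40% with a range from 22% to 58%, an expected step of a number 0.8 percentage points higher from compound 2 to compound 4 (within the scatter).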

Compound 4, percent growth inhibition at one concentration: 62.1%
Estimate against measurement, compound 4: 22.1 percentage points below; the measured number lies above the stated range.
By their numbers in this assay, from the lowest: compound 2; then compounds 3, 4 and 1 (each within the scatter of the next, the first and the last beyond it).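

The position on the thiocarbonyl carbon is not silent in this assay: piperidin-1-yl in place of thiomorpholin-4-yl gives a number 22.9 percentage points higher from compound 2 to compound 4 (beyond the scatter) and thus a step beyond the scatter. With the core of compound 2 held fixed, this ring exchange alone moves the read-out, and the removal of the ring sulfur is what the two structures show as different. No measured property bears on this step.

From the compounds shown here alone, it remains open whether the step carries over to the cores of compound 1 and compound 3. Morpholin-4-yl or a dimethylamino group at this carbon would test how far the read-out follows the ring atom.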